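The source may report more compounds than this note shows. Statements on the series, on what has been measured and on what is new or still open speak of the compounds shown alone.

Compound 2 `CSC1=C(N)C(=O)c2cccnc2C1=O` stands highest of the two numbers measured in a functional assay on HL-60 cells (Homo sapiens) for antiproliferative activity, read by MTT assay, with a stated time of 48 h (on this read-out lower numbers stand for stronger inhibition and higher numbers for weaker inhibition), where it gives 7640 nM. Its nearest neighbour is compound 1 `NC1=C(Cl)C(=O)c2ncccc2C1=O`, which in this assay gives 3260 nM. Within the data shown here, the one step measured so far, a 2.3-fold higher number from compound 1 to compound 2 (0.37 log units; beyond the scatter), came from putting methylsulfanyl in place of chloro on a double-bonded ring carbon and was beyond the scatter, though modest. Compound 3 `CSC1=C(SC)C(=O)c2ncccc2C1=O` has not been measured. It differs from compound 2 by methylsulfanyl in place of amino on a double-bonded ring carbon. Among the measured compounds shown here, no measured step shows this particular exchange, so the expectation rests only on the one step seen: replacing a substituent on the same ring by methylsulfanyl, which in the step from compound 1 to compound 2 gave a higher number. For the measured compounds named here, on that basis compound 3 is expected to show a step of about a 1.4-fold higher number from compound 2 to compound 3 (0.16 log units; within the scatter), toward a higher number, though a step within the scatter cannot be excluded given that only one comparison is at hand. The estimate for compound 3 in this assay is therefore 11000 nM, with a range from 3500 nM to 35000 nM.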

Compound 3, half-maximal inhibitory concentration: 1230 nM
Compound 3: the middle estimate sits 8.9-fold (0.95 log units) above what was measured, outside the stated range (below it).
By their numbers in this assay, from the lowest: compound 3; then compound 1; then compound 2.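

In this assay, among these compounds, the change at this double-bonded ring carbon gives a 6.2-fold lower number from compound 2 to compound 3 (0.79 log units; beyond the scatter) and so runs opposite to the only earlier step, a 2.3-fold higher number from compound 1 to compound 2 (0.37 log units; beyond the scatter), with both steps beyond the scatter. Methylsulfanyl entering the ring therefore has no single direction across these compounds: the number fell when it replaced amino and rose when it replaced chloro, so the group that leaves matters as well as the group that enters. The exchange takes away the amino group with its hydrogen-bond donor and places a second methylsulfanyl next to the first, but nothing available bears on why the number fell.

The compounds shown cannot separate the loss of the donor from the gain of a larger group, since both happen in the same step. From the compounds shown here alone, whether methoxy, methylamino or a longer chain such as ethylsulfanyl at this place would give a number nearer that of compound 2 or that of compound 3 stays open.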